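Replacing a Fluorophenoxy Arm with Tetrahydroquinoline on a Shared Core

The source may report more compounds than this note shows. Statements on the series, on what has been measured and on what is new or still open speak of the compounds shown alone.

Measured compounds:
compound 1 `COc1ccc2[nH]c(C(=O)N3CC(=O)N(Cc4ccccc4)[C@@H](COc4ccc(F)cc4)C3)cc2c1` — 33200 nM
compound 2 `COc1ccc2[nH]c(C(=O)N3CC(=O)N(Cc4ccccc4)[C@@H](CN4CCN(c5ccc(F)cc5)CC4)C3)cc2c1` — > 30000 nM
compound 3 `COc1ccc2[nH]c(C(=O)N3CC(=O)N(Cc4cccc(OC(F)F)c4)[C@@H](CN4CCCCC4)C3)cc2c1` — 12100 nM

All three compounds share one core and were tested in an ADME assay on Vero cells (Chlorocebus sabaeus) for cytotoxicity, with a stated time of 7 days; on this read-out higher numbers stand for lower toxicity in this test and lower numbers for higher toxicity in this test. Compound 1 gives 33200 nM, the higher of the two numbers that came out of this assay, so it is the less toxic of those two. Compound 3 gives 12100 nM, a lower number, and the gap to compound 1 lies beyond the scatter of the test. For compound 2 the test reports only a limit, namely (the limit of > 30000 nM in this assay, at which 1 of the 3 values shown sits).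

The compound not yet measured is compound 4 `COc1ccc2[nH]c(C(=O)N3CC(=O)N(Cc4ccccc4)[C@@H](CN4CCCc5ccccc54)C3)cc2c1`. It differs from compound 1 in one place: 1,2,3,4-tetrahydroquinolin-1-yl in place of 4-fluorophenoxy on a saturated chain carbon bound to a saturated ring carbon. Among the compounds with values here, no measured pair shows this exact change, so its effect can only be anticipated. The step of a 1.8-fold lower number from compound 1 to compound 4 (0.27 log units; within the scatter) is expected to be small and toward a lower number, near the edge of the scatter. Compound 4 is therefore expected to give about 18000 nM, within a range from 8000 nM to 40000 nM.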

Compound 4, half-maximal cytotoxic concentration: > 100000 nM
Compound 4: only a limit was reported; the forecaster's own chance of this, stated with the estimate: 25%; middle value at least 5.5-fold (0.74 log units) from the limit.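

At the saturated chain carbon bound to a saturated ring carbon, putting 1,2,3,4-tetrahydroquinolin-1-yl in place of 4-fluorophenoxy gives an at least 3.0-fold higher number from compound 1 to compound 4 (0.47 log units; beyond the scatter). Within the data shown here, the earlier compounds included no pair differing in one place, so this is the first direct reading of a single change at this position, and it points toward lower toxicity in this assay. The result for compound 4 is a limit and not a number: the limit of > 100000 nM in this assay, at which 1 of the 4 values shown sits.

On these data alone, the true size of the step therefore stays open, as does whether it follows from the ring nitrogen that enters, the oxygen and fluorine that leave, or the larger group as a whole. A plain phenoxy group or a morpholine ring at the same place would help separate these possibilities.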